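This account rests on a few compounds, and the source may have more. Where it says the series, first, only, none or still open, it means among the compounds named here.

In a functional assay on the whole organism (strain L.) for inhibition, with Echinochloa crus-galli as the target, with a stated time of 72 h, tested at 10 mg/L (on this read-out lower numbers stand for less inhibition of growth and higher numbers for more inhibition of growth at the one concentration tested), compound 3 `Cc1cc(Cl)nc(NC(=S)NC(=O)c2c(-c3ccc(Cl)cc3Cl)noc2C)n1` gives -6.84%, the lowest of the three numbers. Compound 1 `COc1cc(Cl)nc(NC(=S)NC(=O)c2c(-c3ccc(Cl)cc3Cl)noc2C)n1` gives 18.5% and compound 2 `Cc1onc(-c2ccc(Cl)cc2Cl)c1C(=O)/N=c1/nc2nc(Cl)cc(C)n2s1` gives 25.8%. One single-point step is measured, a number 25.3 percentage points lower from compound 1 to compound 3 (beyond the scatter), for methyl in place of methoxy on an aromatic carbon. Compound 4 `COc1cc(OC)nc(NC(=S)NC(=O)c2c(-c3ccc(Cl)cc3Cl)noc2C)n1` differs from compound 3 by 4,6-dimethoxypyrimidin-2-yl in place of 4-chloro-6-methylpyrimidin-2-yl on an amide-type nitrogen. For the measured compounds named here, no measured step covers this exact change; the one step measured bears on it, as it reverses methyl back to methoxy and adds a second methoxy where a chlorine stood, so it points in the opposite direction and is of modest size. The step of a number 26.8 percentage points higher from compound 3 to compound 4 (beyond the scatter) is therefore expected to run upward, beyond the scatter. Compound 4 is estimated at 20%, within 5% to 40%.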

Compound 4, percent growth inhibition at one concentration: 21.8%
Estimate against measurement, compound 4: 1.8 percentage points below; the measured number falls inside the stated range.
By their numbers in this assay, from the lowest: compound 3; then compounds 1, 4 and 2 (each within the scatter of the next).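

In this assay, 4,6-dimethoxypyrimidin-2-yl in place of 4-chloro-6-methylpyrimidin-2-yl on the amide-type nitrogen gives a number 28.6 percentage points higher from compound 3 to compound 4 (beyond the scatter) and so lifts the series out of the low number of compound 3. Methoxy in place of chloro on an aromatic carbon gives a number 3.3 percentage points higher from compound 1 to compound 4 (within the scatter) and so does not separate these two groups here, leaving methyl in place of methoxy as the only single-place change with a step beyond the scatter. Nothing available explains either step. Open, as far as these compounds go, is whether an ethoxy or a dimethylamino group on that aromatic carbon would keep the number of compound 4.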